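Fluorination of the cinnamamide aryl ring in trimethoxybenzophenones

This account rests on a few compounds, and the source may have more. Where it says the series, first, only, none or still open, it means among the compounds named here.

Compound 1 `COc1ccc(/C=C/C(=O)Nc2cc(C(=O)c3cc(OC)c(OC)c(OC)c3)cc(OC)c2OC)cc1OC` carries a 3,4-dimethoxyphenyl on a double-bonded chain carbon bound to a double-bonded chain carbon, and in a functional assay on HeLa cells (Homo sapiens) for cytotoxicity, read by MTT assay, with a stated time of 72 h (a higher number here means a weaker inhibitor, a lower number a stronger inhibitor), compound 1 gives 2700 nM. Compound 2 `COc1cc(C(=O)c2cc(OC)c(OC)c(OC)c2)cc(NC(=O)/C=C/c2ccc(F)cc2)c1OC` carries a 4-fluorophenyl in that place, and in this assay compound 2 gives 900 nM. Among the measured compounds shown here, the change was a 3.0-fold lower number from compound 1 to compound 2 (0.48 log units; beyond the scatter), so compound 2 stands with the lower of the two numbers measured so far.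

Compound 3 `COc1cc(C(=O)c2cc(OC)c(OC)c(OC)c2)cc(NC(=O)/C=C/c2cc(F)c(F)c(F)c2)c1OC` differs from compound 2 in one place: 3,4,5-trifluorophenyl in place of 4-fluorophenyl on a double-bonded chain carbon bound to a double-bonded chain carbon. For the measured compounds named here, no measured step covers this change directly. Going by the values given here, the only step known, from compound 1 to compound 2, swapped a methoxy-bearing ring for a fluorine-bearing one and was modest; the move from compound 2 to compound 3 keeps a fluorinated ring and only varies how it is fluorinated. He therefore expects at most a small step in this assay, likely within the scatter, with no firm direction.

His estimate for compound 3 in this assay is 750 nM, within 250 nM to 2200 nM, which is expected to amount to a 1.2-fold lower number from compound 2 to compound 3 (0.08 log units; within the scatter).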

Compound 3, half-maximal inhibitory concentration: 5000 nM
For compound 3 the middle estimate is 6.7-fold (0.82 log units) below the measured one, and the stated range ends below it.
By their numbers in this assay, from the lowest: compound 2; then compounds 1 and 3 (each within the scatter of the next).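

Adding fluorine at this place on the chain is not a neutral change: in this assay the move from 4-fluorophenyl to 3,4,5-trifluorophenyl gives a 5.6-fold higher number from compound 2 to compound 3 (0.74 log units; beyond the scatter) and so runs against the direction of the earlier step away from 3,4-dimethoxyphenyl. A fluorinated ring here therefore does not by itself bring the lower number, since the other comparison reads a 1.9-fold higher number from compound 1 to compound 3 (0.27 log units; within the scatter) and leaves 3,4,5-trifluorophenyl and 3,4-dimethoxyphenyl indistinguishable in this assay, with only the 4-fluorophenyl ring of compound 2 standing apart from both. The data shown offer no measurement that could account for this reversal.

The compounds shown leave open whether a plain phenyl ring or a 4-chlorophenyl ring would stand with compound 2 or with the other two, and where a 3,4-difluorophenyl ring would fall between the single and the triple fluorine pattern. They also leave open whether the step from 4-fluorophenyl to 3,4,5-trifluorophenyl would keep its size if a saturated ethyl link took the place of the double-bonded chain carbons.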